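This account rests on a few compounds, and the source may have more. Where it says the series, first, only, none or still open, it means among the compounds named here.

In an assay on HEK293 cells for inhibition of N-acylethanolamine-hydrolyzing acid amidase (Rattus norvegicus), read by LC-MS, with a stated time of 30 min (a higher number here means a weaker inhibitor, a lower number a stronger inhibitor), compound 1 `Cc1cccc(CCCCCCC(=O)N2CCCC2)c1` gives 8300 nM. Compound 2 `O=C(CCCCCCc1cccc(F)c1)N1CCCC1` differs from it only by a fluoro in place of methyl on an aromatic carbon, and in this assay compound 2 gives 7300 nM. That single change, a 1.1-fold lower number from compound 1 to compound 2 (0.06 log units; within the scatter), did not move the number beyond the scatter. Compound 3 `Cc1ccccc1-c1ccc(CCC(=O)N2CCCC2)cc1` has a shorter chain between the amide and the aromatic part, and a second aromatic ring attached to the first. For compound 3 this assay reports only a limit, > 100000 nM. This is the limit of the assay (the limit of > 100000 nM in this assay, at which 1 of the 3 values shown sits), so no number is known for compound 3.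

Compound 4 `O=C(CCc1ccc(-c2ccc(F)cc2)cc1)N1CCCC1` keeps the core of compound 3 and changes the outer ring: 4-fluorophenyl in place of 2-methylphenyl on an aromatic carbon. Within the data shown here, the one measured step, a 1.1-fold lower number from compound 1 to compound 2 (0.06 log units; within the scatter), also replaced a methyl with a fluorine on an aromatic carbon and stayed within the scatter, so the fluorine itself gives no reason to expect a large step; the rest of the change, from 2-methylphenyl to 4-fluorophenyl as a whole, has no measured counterpart here. Compound 3 stands at a limit, > 100000 nM. Compound 4 is therefore expected to remain weak, with an estimated step of a number no higher from compound 3 to compound 4 (the limit leaves the size open) and an estimated value of 100000 nM, between 30000 nM and 300000 nM.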

Compound 4, half-maximal inhibitory concentration: 3400 nM
Beside the measured number, compound 4's estimate is 29-fold (1.47 log units) above it; the whole stated range lies above it.
By their numbers in this assay, from the lowest: compound 4; then compounds 2 and 1 (each within the scatter of the next). At a limit, above all of these: compound 3.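

In this assay, the swap of 2-methylphenyl for 4-fluorophenyl on an aromatic carbon, para to a group of 9 heavy atoms, gives an at least 29-fold lower number from compound 3 to compound 4 (1.46 log units; beyond the scatter). The only earlier step, a 1.1-fold lower number from compound 1 to compound 2 (0.06 log units; within the scatter), also exchanged a methyl for a fluorine but stayed within the scatter, so this is the first change among these compounds to move the number beyond the scatter, and it shows that the outer ring at this position can matter a great deal. Compound 3 stands at a limit of the assay, so the step has a lower bound and its full size stays open: the limit of > 100000 nM in this assay, at which 1 of the 4 values shown sits.

The swap changes the group and also where it sits on the outer ring, and the compounds shown cannot tell which of the two carries the step. Going by these compounds, how an unsubstituted phenyl ring would read here stays open, as does the effect of a nitrile or a carboxylic acid in place of the fluorine.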